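The source may hold more compounds than are shown below. What is called first, only, known or untested is meant among the compounds shown, and "the series" means these compounds.

In a functional assay on MDA-MB-231 cells (Homo sapiens) for antiproliferative activity, read by CCK-8 assay, with a stated time of 48 h (a lower number here means a stronger inhibitor, a higher number a weaker inhibitor), compound 2 (`CNC(=O)/C=C/CNCCOc1ccc(Oc2c(-c3ccc(F)cc3)sc3cc(O)ccc23)cc1`) gives > 50000 nM, which is a limit of the assay and not a number. Compound 1 (`C=C(C)C(=O)NCCOc1ccc(Oc2c(-c3ccc(F)cc3)sc3cc(O)ccc23)cc1`) gives > 50000 nM, also a limit. Compound 3 (`O=C(/C=C/CN1CC(Oc2ccc(Oc3c(-c4ccc(F)cc4)sc4cc(O)ccc34)cc2)C1)N1CCCC1`) gives > 50000 nM, again a limit. The whole series therefore comes down to the limit of > 50000 nM in this assay, at which 3 of the 3 values shown sit, and compound 2 has no numerical place within it.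

Compound 4 (`C/C=C/C(=O)NCCOc1ccc(Oc2c(-c3ccc(F)cc3)sc3cc(O)ccc23)cc1`) differs from compound 2 on an amine nitrogen whose other neighbour is a saturated chain carbon, where (prop-1-en-1-yl)carbonyl stands in place of 3-(methylcarbamoyl)prop-2-en-1-yl: (prop-1-en-1-yl)carbonyl in place of 3-(methylcarbamoyl)prop-2-en-1-yl on an amine nitrogen.

Going by the values given here, the one measured step that bears on this change is a step that the two limits leave unreadable from compound 1 to compound 2. It also puts 3-(methylcarbamoyl)prop-2-en-1-yl on an amine nitrogen, in place of (1-methylethenyl)carbonyl, but it gives no size to carry over. With limits at both ends of that step, no step beyond the scatter is expected in this assay, and no direction can be assigned. The expected change is a number no higher from compound 2 to compound 4 (the limit leaves the size open). Compound 4 is estimated at 50000 nM, with an expected range of 25000 nM to 100000 nM, and it is expected most probably to be reported as a limit again.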

Compound 4, half-maximal inhibitory concentration: > 50000 nM
Compound 4 ended at the assay's limit (the forecaster's own chance of this, stated with the estimate: 80%); the middle value sits exactly at the limit.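

In this assay compound 4 gives > 50000 nM, which is a limit and not a number. No size can therefore be read for the steps to compound 4 from compound 1 or compound 2. The compounds shown leave open how these changes on the amine nitrogen and carbonyl carbon affect activity, since every result is a limit: the limit of > 50000 nM in this assay, at which 4 of the 4 values shown sit.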